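This account rests on a few compounds, and the source may have more. Where it says the series, first, only, none or still open, it means among the compounds named here.

Of the compounds shown here, two have numbers so far. Compound 1 `CCCCc1c(-c2ccc(C(=O)NS(=O)(=O)c3ccc4ccccc4c3)cc2C(=O)N2CCc3ccccc3C2)c(CO)nn1-c1ccc(-c2ccccc2)cc1` gives 7 nM in an assay on isolated protein for inhibition of Apoptosis regulator Bcl-2 (Homo sapiens), read by fluorescence polarization, with a stated time of 60 min; on this read-out higher numbers stand for weaker inhibition and lower numbers for stronger inhibition. Among the measured compounds shown here, compound 2 `CCCCc1c(-c2ccc(C(=O)NS(=O)(=O)c3ccc4ccccc4c3)cc2C(=O)N2CCc3ccccc3C2)c(CO)nn1-c1ccc(CCO)cc1` gives 20 nM in this assay and thus stands at the higher end of the two; the only measured step, a 2.9-fold higher number from compound 1 to compound 2 (0.46 log units; beyond the scatter), reflects the exchange of phenyl for 2-hydroxyethyl on an aromatic carbon. Compound 3 `CCCCc1c(-c2ccc(C(=O)NS(=O)(=O)c3ccc4ccccc4c3)cc2C(=O)N2CCc3ccccc3C2)c(CO)nn1-c1ccc(CCCO)cc1` is not yet measured. It differs from compound 2 by hydroxymethyl in place of hydroxy on a saturated chain carbon, two bonds along the chain from an aromatic carbon; read one bond further out, 2-hydroxyethyl becomes 3-hydroxypropyl. For the measured compounds named here, no measured step bears on lengthening this chain: the step from compound 1 to compound 2 changes the kind of group, not its length, and gives no direction for this change. The expected step is therefore no change at the digits printed from compound 2 to compound 3 (within the scatter), within the scatter. Compound 3 is expected to give 20 nM in this assay, with a range from 8 nM to 50 nM.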

Compound 3, half-maximal inhibitory concentration: 14 nM
Compound 3: the middle estimate sits 1.4-fold (0.15 log units) above what was measured; low and high end bracket the measured number.
By their numbers in this assay, from the lowest: compounds 1, 3 and 2 (each within the scatter of the next, the first and the last beyond it).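

Lengthening 2-hydroxyethyl to 3-hydroxypropyl on this chain produces no readable change in this assay (a 1.4-fold lower number from compound 2 to compound 3 (0.15 log units; within the scatter)), so the first measured variation in chain length at this position lies within the scatter. Against phenyl, 3-hydroxypropyl also stays within the scatter (a 2.0-fold higher number from compound 1 to compound 3 (0.30 log units; within the scatter)), whereas 2-hydroxyethyl lies beyond it (a 2.9-fold higher number from compound 1 to compound 2 (0.46 log units; beyond the scatter)); an open-chain hydroxyalkyl group can therefore stand in for phenyl here without a readable loss, at least in compound 3. Nothing available gives a cause for these numbers.

Still open, going by these compounds, is whether a longer chain, such as 4-hydroxybutyl, keeps the number in this assay in the same range. Also open, on these data alone, is whether the hydroxy matters at all, which a plain propyl group, a 3-aminopropyl group or a carboxylic acid in its place would address.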